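Shortening a Hydroxyalkyl Side Chain: Expected Cytotoxicity

The source may report more compounds than this note shows. Statements on the series, on what has been measured and on what is new or still open speak of the compounds shown alone.

Measured compounds:
- compound 1, `CCCCCC(O)c1cc(OC)c2c(c1OC)C(=O)C=CC2=O`: 0.066 ug/mL
- compound 2, `CCCCCC(O)C1=CC(=O)c2c(OC)ccc(OC)c2C1=O`: 0.378 ug/mL
- compound 3, `CCC(O)c1cc(OC)c2c(c1OC)C(=O)C=CC2=O`: 0.085 ug/mL

In a functional assay on L1210 cells (Mus musculus) for cytotoxicity (a higher number here means that more compound is needed for the effect, a lower number that less compound is needed), compound 1 gives 0.066 ug/mL, compound 3 gives 0.085 ug/mL, and compound 2 gives 0.378 ug/mL. Compound 2 therefore gives the highest number of the three; its gaps to compound 3 and to compound 1 both lie beyond the scatter, so more of compound 2 is needed for the same effect than of either other compound.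

Compound 4, `COc1ccc(OC)c2c1C(=O)C=C(C(C)O)C2=O`, differs from compound 2 by hydrogen in place of butyl on a saturated chain carbon, two bonds along the chain from a double-bonded ring carbon and an oxygen on a saturated carbon. Going by the values given here, one measured step bears on this change: a chain was likewise removed from a saturated carbon that also carries an oxygen, and a 1.3-fold higher number from compound 1 to compound 3 (0.11 log units; within the scatter). That removal left the number essentially unchanged. The change from compound 2 to compound 4 takes away a somewhat longer chain, and the chain sits on a carbon attached to a double-bonded ring carbon rather than an aromatic carbon, so the analogy is imperfect, but nothing in the measured data points to a large shift.

The step from compound 2 to compound 4 is therefore expected to be small, a 1.2-fold higher number from compound 2 to compound 4 (0.08 log units; within the scatter). Compound 4 is estimated at 0.45 ug/mL, with a range from 0.2 ug/mL to 1 ug/mL.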

Compound 4, concentration for half-maximal effect: 0.487 ug/mL
Estimate against measurement, compound 4: 1.1-fold (0.03 log units) below; the range from low to high includes it.
By their numbers in this assay, from the lowest: compounds 1 and 3 (each within the scatter of the next); then compounds 2 and 4 (each within the scatter of the next).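

In this assay, hydrogen in place of butyl on this saturated chain carbon gives a 1.3-fold higher number from compound 2 to compound 4 (0.11 log units; within the scatter) and stays within the scatter, so on this core the outer part of the 1-hydroxyhexyl chain can be cut back to 1-hydroxyethyl without a change that can be told from repeat measurements. Until now, shortening a chain on a saturated carbon that carries an oxygen had been seen only on the other core, as a 1.3-fold higher number from compound 1 to compound 3 (0.11 log units; within the scatter) shows, so the two listed steps now agree on two different cores, and neither goes against the other. The data give no measured property that would explain why chain length matters so little for these compounds.

Every compound shown keeps the oxygen on that saturated carbon and carries a chain no longer than pentyl beyond it, so it remains open whether the number would hold with an amine in place of that oxygen. A chain longer than pentyl, or a carboxylic acid at the end of the chain, also remains an open case for both cores.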